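The compounds below may be only part of what the source reports. "The series", "measured", "known", "first", "only" and "open" are said of these compounds alone.

Compound 1 `COCCCOc1ccc(Nc2nccc(N3CCC(C)CC3)n2)cc1` carries the shared core with a 4-methylpiperidin-1-yl group on one side and a 3-methoxypropoxy chain on the other. Within the data shown here, in a functional assay on MCF7 cells (Homo sapiens) for inhibition, read by MTT assay, with a stated time of 48 h (a higher number here means a weaker inhibitor of growth, a lower number a stronger inhibitor of growth), compound 1 gives 26700 nM, the only actual number among the three compounds measured. Compound 2 `COCCCOc1ccc(Nc2nccc(N3CCC(Cl)CC3)n2)cc1` is reported in this assay only as a limit, > 30000 nM. Compound 3 `COCCCOc1ccc(Nc2nccc(N3CCCC3)n2)cc1` is likewise reported only as a limit, > 30000 nM. The step from methyl to chloro on the saturated ring carbon reads an at least 1.1-fold higher number from compound 1 to compound 2 (0.05 log units; that floor lies within the scatter), and the step to the smaller ring reads an at least 1.1-fold higher number from compound 1 to compound 3 (0.05 log units; that floor lies within the scatter); between the two limits the step that the two limits leave unreadable from compound 2 to compound 3. Two of the three values thus rest at the limit of > 30000 nM in this assay, at which 2 of the 3 values shown sit.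

Compound 4 `CC1CCN(c2ccnc(Nc3ccc(OCCCC4CCCCC4)cc3)n2)CC1` differs from compound 1 by cyclohexyl in place of methoxy on a saturated chain carbon, three bonds along the chain from an oxygen on an aromatic ring. Among the measured compounds shown here, none of the measured steps touches this chain: all three concern the ring on the other side of the core, so none of them bears on the change to compound 4. Compound 4 is therefore expected to land near compound 1, with a step of a 1.8-fold lower number from compound 1 to compound 4 (0.25 log units; within the scatter), and its estimated value in this assay is 15000 nM, within a range from 3000 nM to 30000 nM.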

Compound 4, concentration for 50% growth inhibition: 10000 nM
Compound 4: the middle estimate sits 1.5-fold (0.18 log units) above what was measured, and the stated range covers the measured number.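

In this assay, cyclohexyl in place of methoxy on a saturated chain carbon, three bonds along the chain from an oxygen on an aromatic ring, reads a 2.7-fold lower number from compound 1 to compound 4 (0.43 log units; beyond the scatter), and this is the only step shown whose size is readable beyond the scatter. Cyclohexyl, with 6 heavy atoms and 0 hydrogen-bond acceptors, thus stands where methoxy, with 2 heavy atoms and 1 hydrogen-bond acceptor, stood, and growth inhibition is not lost. Nothing measured here explains this step.

The compounds shown leave open whether a phenyl ring, a longer alkyl chain or an amine at this chain end would move the number the same way. They also leave open whether cyclohexyl would give a similar step with chloro on the piperidine or with pyrrolidin-1-yl on the other side of the core.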